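The source may hold more compounds than are shown below. What is called first, only, known or untested is meant among the compounds shown, and "the series" means these compounds.

Measured compounds:
Compound 1 `O=S(=O)(Nc1ccc2oc(-c3ccccc3)nc2c1)c1cccc(C(F)(F)F)c1` gives in an assay on cells for inhibition of HSP60/HSP10 (Homo sapiens), with a stated time of 60 min (a higher number here means a weaker inhibitor, a lower number a stronger inhibitor), a limit of > 100000 nM.
Compound 2 `O=S(=O)(Nc1ccc2oc(-c3ccccc3)nc2c1)c1cccc(Cl)c1` gives a limit of > 100000 nM.

Compound 2 therefore stands only at a limit in this assay, with no number shown for it. The step that the two limits leave unreadable from compound 1 to compound 2 cannot be read, as both values sit at the limit described by the limit of > 100000 nM in this assay, at which 2 of the 2 values shown sit. Compound 3 `CCc1ccc(S(=O)(=O)Nc2ccc3oc(-c4ccccc4)nc3c2)cc1` differs from compound 2 by 4-ethylphenyl in place of 3-chlorophenyl on a sulfonyl sulfur. Among the compounds with values here, the one measured step bears on this change only by showing both of its compounds at the limit, so no step beyond the scatter is expected in this assay. Compound 3 is expected to give about 150000 nM, between 30000 nM and 1000000 nM, most likely again reported as a limit. The step that the limit leaves unreadable from compound 2 to compound 3 is thus estimated as essentially none.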

Compound 3, half-maximal inhibitory concentration: > 100000 nM
Compound 3 gave a limit, no number; the forecaster's own chance of this, stated with the estimate: 85%; the middle value is on the limit's open side.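

In this assay compound 3 gives > 100000 nM, which is a limit. Within the data shown here, compound 2 is also at a limit, so no step between compound 2 and compound 3 can be read. The compounds shown leave open which change, if any, would give a readable value, as all of them sit at one limit: the limit of > 100000 nM in this assay, at which 3 of the 3 values shown sit.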